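Benzofuran amidoxime series: hydroxymethyl added to the core

The source may report more compounds than this note shows. Statements on the series, on what has been measured and on what is new or still open speak of the compounds shown alone.

Measured so far, in an assay on isolated protein for inhibition of Indoleamine 2,3-dioxygenase 1 (Homo sapiens), read by spectrophotometry; a lower number here means a stronger inhibitor, a higher number a weaker inhibitor:
compound 1 `O/N=C(/Nc1cccc(F)c1)c1ccc2occc2c1` gives 32700 nM
compound 2 `O/N=C(/Nc1cccc(Cl)c1)c1ccc2occc2c1` gives 690 nM
compound 3 `O/N=C(/Nc1cccc(COc2ccccc2)c1)c1ccc2occc2c1` reaches only the limit > 30000 nM

Of the two numbers read, compound 1 stands highest; the step of a 47-fold lower number from compound 1 to compound 2 (1.68 log units; beyond the scatter) is the only one with two readable ends. The limit of > 30000 nM in this assay, at which 1 of the 3 values shown sits, sits on compound 3 alone. The step that the limit leaves unreadable from compound 1 to compound 3 therefore cannot be sized, while an at least 43-fold higher number from compound 2 to compound 3 (1.63 log units; beyond the scatter) can at least be bounded.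

Compound 4 `OCc1cc2cc(/C(=N\O)Nc3cccc(F)c3)ccc2o1` is the next to be measured. It differs from compound 1 by hydroxymethyl in place of hydrogen on an aromatic carbon. For the measured compounds named here, every measured step so far changes the group on the aniline ring and leaves the shared core as it stands in compound 1; none of them bears on a change at the core, so no measured step gives a direct guide here.

On that basis the expectation is a step from compound 1 to compound 4 of no size beyond the scatter, a 1.1-fold lower number from compound 1 to compound 4 (0.04 log units; within the scatter). Compound 4 is estimated at 30000 nM, with a range from 8000 nM to 100000 nM.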

Compound 4, half-maximal inhibitory concentration: 1700 nM
The estimate for compound 4 lay 18-fold (1.25 log units) above the measured number; the measured number lies below the stated range.
By their numbers in this assay, from the lowest: compound 2; then compound 4; then compound 1.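

The first change read at the shared core is hydroxymethyl in place of hydrogen on an aromatic carbon next to the ring oxygen, and in this assay it gives a 19-fold lower number from compound 1 to compound 4 (1.28 log units; beyond the scatter) as its step. For the compounds shown here, this position is therefore not silent with fluoro held on the aniline ring, a point the earlier steps could not address because they changed only that ring. Nothing on hand accounts for the size of this step.

A single group at this position cannot separate the part played by the hydroxyl from that of the added carbon, and methyl, aminomethyl or a carboxylic acid there would bear on that question. On these data alone, it also remains open whether hydroxymethyl gives a similar step when chloro, as in compound 2, sits on the aniline ring.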